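Fluoro for Methoxy on a Scaffold Without Measured Activity

A few compounds are considered here, and "the series" means these few. Any claim that something is new, unique, unknown or untested is made for them only; others in the source may bear on it.

Compound 2 `COc1ccccc1Nc1nc(-c2cccc(F)c2)nc2ccc(F)cc12` is one of two compounds tested in a functional assay on COLO 205 cells (Homo sapiens) for cytotoxicity, read by MTT assay, with a stated time of 48 h (on this read-out higher numbers stand for weaker inhibition and lower numbers for stronger inhibition), and both sit only at a limit. In this assay compound 2 gives > 50000 nM, a limit of the assay rather than a number. Compound 1 `Fc1ccc2nc(-c3ccccc3)nc(Nc3ccccc3)c2c1` likewise gives > 50000 nM, again a limit. The shared position the limit of > 50000 nM in this assay, at which 2 of the 2 values shown sit, is all the measured values show. Compound 3 `Fc1cccc(-c2nc(Nc3ccccc3F)c3cc(F)ccc3n2)c1` differs from compound 2 by fluoro in place of methoxy on an aromatic carbon. Within the data shown here, with no measured step of this kind, no shift beyond the scatter is expected. Compound 3 is estimated at 60000 nM, between 20000 nM and 200000 nM. The expected step is a step that the limit leaves unreadable from compound 2 to compound 3, most likely again only a limit.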

Compound 3, half-maximal inhibitory concentration: > 50000 nM
Compound 3: only a limit was reported; the forecaster's own chance of this, stated with the estimate: 80%; the middle value does not contradict the limit.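

Compound 3, like compound 2, sits only at a limit, so no step between the two can be read: the limit of > 50000 nM in this assay, at which 3 of the 3 values shown sit.

The compounds shown leave open whether any change to the shared core gives a readable value in this assay.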